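The source may hold more compounds than are shown below. What is called first, only, known or untested is meant among the compounds shown, and "the series" means these compounds.

Of the compounds shown here, three sharing one core have been tested in a functional assay on the whole organism with Rattus norvegicus as the target; a lower number here means that less compound is needed, a higher number that more compound is needed for the effect. Compound 1 `Nc1ccc2nc(N)sc2c1` gives only a limit of the assay, > 10 mg/kg, and no number. Compound 2 `Nc1nc2ccc(C(F)(F)C(F)(F)F)cc2s1` gives 2.5 mg/kg in this assay. Compound 3 `C=CCn1c(=N)sc2cc(OC(F)(F)F)ccc21` gives 7 mg/kg in this assay, the higher of the two numbers, and its gap to compound 2 lies beyond the usual scatter. Compound 4 `CNS(=O)(=O)CCn1c(=N)sc2cc(OC(F)(F)F)ccc21` differs from compound 3 in one place: (methylsulfamoyl)methyl in place of vinyl on a saturated chain carbon bound to an aromatic nitrogen. Within the data shown here, no measured pair shows a step of this kind, so the expectation rests on compound 3 alone. A small rise in dose is expected, a 1.3-fold higher number from compound 3 to compound 4 (0.11 log units; within the scatter), perhaps no larger than the scatter. Compound 4 is therefore estimated at 9 mg/kg in this assay, with a range from 4 mg/kg to 20 mg/kg.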

Compound 4, dose for half-maximal effect: 4 mg/kg
For compound 4 the middle estimate is 2.3-fold (0.35 log units) above the measured one; the range from low to high includes it.
By their numbers in this assay, from the lowest: compounds 2, 4 and 3 (each within the scatter of the next, the first and the last beyond it). At a limit, above all of these: compound 1.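

Replacing vinyl with (methylsulfamoyl)methyl, on a saturated chain carbon bound to an aromatic nitrogen, gives a 1.8-fold lower number from compound 3 to compound 4 (0.24 log units; within the scatter) in this assay. Among these compounds, this is the first step seen at this place, and the required dose holds within the scatter even though the entering group is larger and brings a hydrogen-bond donor and acceptors that vinyl lacks. Nothing available bears on why the dose holds.

On these data alone, it remains open whether an amine, a carboxylic acid or a longer chain at this place would also hold the dose. A single step also cannot show how far this tolerance extends.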